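Compound 2 to compound 4: 3-fluoropyridin-2-yl replaces pyridazin-3-yl

The compounds below may be only part of what the source reports. "The series", "measured", "known", "first", "only" and "open" are said of these compounds alone.

In an ADME assay on S9 fraction from liver (Rattus norvegicus) for metabolic stability, read by LC-MS, using NADPH, with a stated time of 90 min, tested at 5 uM (a lower number here means that less of the compound is left, a higher number that more of the compound is left), compound 1 `Cn1c(Sc2c(F)cc(C(=O)NO)cc2F)nnc1-c1cccs1` gives 71%. Compound 2 `Cn1c(Sc2c(F)cc(C(=O)NO)cc2F)nnc1-c1cccnn1` gives 58%, and compound 3 `Nc1ccc(-c2nnn(Cc3c(F)cc(C(=O)NO)cc3F)n2)cc1` gives 48%, which lies within the scatter of compound 2. Among the compounds with values here, only one measured step bears on this place: a number 13 percentage points lower from compound 1 to compound 2 (beyond the scatter), a modest change beyond the scatter with pyridazin-3-yl in place of thiophen-2-yl. Compound 4 `Cn1c(Sc2c(F)cc(C(=O)NO)cc2F)nnc1-c1ncccc1F` has not yet been measured. Its difference from compound 2 is 3-fluoropyridin-2-yl in place of pyridazin-3-yl on an aromatic carbon, with 3-fluoropyridin-2-yl in place of pyridazin-3-yl on an aromatic carbon. With that single step as the guide, only a small rise within the scatter is expected, and the estimated change is a number 4 percentage points higher from compound 2 to compound 4 (within the scatter). For compound 4 the expected value is 62%, with an estimated range from 46% to 78%.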

Compound 4, percent of the compound remaining: 70%
Compound 4: the middle estimate sits 8 percentage points below what was measured; the measured number falls inside the stated range.
By their numbers in this assay, from the lowest: compounds 3 and 2 (each within the scatter of the next); then compounds 4 and 1 (each within the scatter of the next).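

In this assay, the position on the aromatic carbon proves sensitive to which six-membered ring it carries, with 3-fluoropyridin-2-yl replacing pyridazin-3-yl giving a number 12 percentage points higher from compound 2 to compound 4 (beyond the scatter). Against the five-membered thiophen-2-yl, the same group gives a number 1 percentage points lower from compound 1 to compound 4 (within the scatter), so the drop seen with pyridazin-3-yl is not shared by every six-membered aromatic ring here. Nothing available explains this difference. The compounds shown leave open whether the fluorine or the single ring nitrogen carries the step, which plain pyridin-2-yl could separate. As far as these compounds go, how an amine on that ring would read also remains open.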